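This account rests on a few compounds, and the source may have more. Where it says the series, first, only, none or still open, it means among the compounds named here.

Working notes on the series. Compound 1 `CCCCc1cn(-c2cccc(S(=O)(=O)Nc3ccccc3C(F)(F)F)c2)nn1`, compound 2 `CC(C)CCc1cn(-c2ccc(NC(=O)Nc3ccccc3F)cc2)nn1` and compound 3 `CC(=O)CCc1cn(-c2ccc(NC(=O)Nc3cccc(F)c3)cc2)nn1` have been run in an assay for inhibition of ATP-dependent RNA helicase DDX3X (Homo sapiens), read by FRET, with a stated time of 40 min, in the presence of a further agent that is not named here; a lower number here means a stronger inhibitor, a higher number a weaker inhibitor. In this assay compound 1 gives 400 nM, compound 2 gives 120 nM and compound 3 gives 2400 nM. Compound 2 thus stands lowest of the three numbers, with compound 1 nearest and compound 3 furthest away, both beyond the scatter. Compound 4 `Cc1ccccc1NC(=O)Nc1ccc(-n2cc(CCC(C)C)nn2)cc1` is not yet measured; it differs from compound 2 by methyl in place of fluoro on an aromatic carbon. Within the data shown here, no two measured compounds differ in one place only, so this change has no direct precedent here. The step of a 1.3-fold higher number from compound 2 to compound 4 (0.10 log units; within the scatter) is expected to lie within the scatter, with no clear direction. Compound 4 is estimated at 150 nM, within a range of 60 nM to 400 nM, in this assay.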

Compound 4, half-maximal inhibitory concentration: 170 nM
Compound 4: the middle estimate sits 1.1-fold (0.05 log units) below what was measured; the range from low to high includes it.
By their numbers in this assay, from the lowest: compounds 2 and 4 (each within the scatter of the next); then compound 1; then compound 3.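

Methyl in place of fluoro on an aromatic carbon, ortho to a large group, gives a 1.4-fold higher number from compound 2 to compound 4 (0.15 log units; within the scatter) and is the only one-place comparison available in the series. At this position, 2-fluorophenyl and 2-methylphenyl are therefore not told apart, and the change alone gives no direction. No evidence on hand bears on this result.

As far as these compounds go, whether methoxy, a carboxylic acid or an amine at this position would stay within the scatter of compound 2 remains open. So does the result of having only hydrogen there.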